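Notes on replacing chloro in compound 1

A few compounds are considered here, and "the series" means these few. Any claim that something is new, unique, unknown or untested is made for them only; others in the source may bear on it.

- compound 1 `O=C(CCc1cccc2c1B(O)OC2)Nc1ccc(Cl)cc1`: 5000 nM
- compound 2 `C#Cc1ccc(NC(=O)CCc2cccc3c2B(O)OC3)cc1`: 6300 nM

In a functional assay on SK-OV-3 cells (Homo sapiens) for antiproliferative activity, read by MTT assay, with a stated time of 72 h (a lower number here means a stronger inhibitor, a higher number a weaker inhibitor), compound 1, at 5000 nM, lies within the scatter of compound 2, at 6300 nM. Compound 3 `CC(C)(C)OC(=O)NCc1ccc(NC(=O)CCc2cccc3c2B(O)OC3)cc1` is not yet measured. Its difference from compound 1 is ((tert-butoxycarbonyl)amino)methyl in place of chloro on an aromatic carbon. Among the compounds with values here, one measured step bears on this place: a 1.3-fold higher number from compound 1 to compound 2 (0.10 log units; within the scatter). That single step, with ethynyl entering, is a thin guide, so no step beyond the scatter is expected in this assay, though with wide uncertainty. The expected value for compound 3 is 6000 nM, with an estimated range of 2500 nM to 14000 nM. The expected step is a 1.2-fold higher number from compound 1 to compound 3 (0.08 log units; within the scatter).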

Compound 3, half-maximal inhibitory concentration: 2000 nM
Compound 3: the middle estimate sits 3.0-fold (0.48 log units) above what was measured; measured number outside the range, below it.
By their numbers in this assay, from the lowest: compound 3; then compounds 1 and 2 (each within the scatter of the next).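

In this assay, this position can move the number beyond the scatter, which the earlier chloro and ethynyl pair did not show: ((tert-butoxycarbonyl)amino)methyl gives a 2.5-fold lower number from compound 1 to compound 3 (0.40 log units; beyond the scatter) and a 3.2-fold lower number from compound 2 to compound 3 (0.50 log units; beyond the scatter). Both steps are modest, and the change adds heavy atoms, a hydrogen-bond donor and hydrogen-bond acceptors all at once, so these features cannot be separated here. No supporting data bear on why the number falls.

Open, as far as these compounds go, is whether the tert-butoxycarbonyl part matters, or whether a free aminomethyl group would give a similar number. Also open, from the compounds shown here alone, is how a carboxylic acid or a longer chain at this position would compare.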